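Swapping Allyloxy for Cyclopropylamino on the Shared Core

A few compounds are considered here, and "the series" means these few. Any claim that something is new, unique, unknown or untested is made for them only; others in the source may bear on it.

Measured in a functional assay on HFF cells (Homo sapiens) for cytotoxicity; a higher number here means that more compound is tolerated, a lower number that less compound is tolerated:
- compound 1 `CCCCCOc1nc(N)nc2c1ncn2/C=C1/C[C@@H]1CO`: 41900 nM
- compound 2 `CCCCCSc1nc(N)nc2c1ncn2/C=C1/C[C@@H]1CO`: 215000 nM
- compound 3 `C=CCOc1nc(N)nc2c1ncn2/C=C1/C[C@@H]1CO`: 220000 nM

Compound 3 holds the highest of these three numbers, but that lead is real on one side only. The gap on the other side lies within the scatter: a 1.0-fold higher number from compound 2 to compound 3 (0.01 log units; within the scatter). The clear gap is a 5.3-fold higher number from compound 1 to compound 3 (0.72 log units; beyond the scatter).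

The next compound, compound 4 `Nc1nc(NC2CC2)c2ncn(/C=C3/C[C@@H]3CO)c2n1`, carries cyclopropylamino in place of allyloxy on an aromatic carbon. Going by the values given here, two measured steps touch this same carbon and bear on the change, and both are modest: a 5.1-fold higher number from compound 1 to compound 2 (0.71 log units; beyond the scatter) and a 5.3-fold higher number from compound 1 to compound 3 (0.72 log units; beyond the scatter). Among the compounds with values here, no measured compound has a nitrogen-linked group or a ring there, so this is an extrapolation. In this assay, no step beyond the scatter is therefore expected, with a slight lean towards a lower number. The expected change is a 1.5-fold lower number from compound 3 to compound 4 (0.17 log units; within the scatter). Compound 4 is estimated at 150000 nM, with an expected range of 50000 nM to 350000 nM.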

Compound 4, half-maximal cytotoxic concentration: 213000 nM
Compound 4: the middle estimate sits 1.4-fold (0.15 log units) below what was measured, and the stated range covers the measured number.
By their numbers in this assay, from the lowest: compound 1; then compounds 4, 2 and 3 (each within the scatter of the next).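

In this assay this aromatic carbon accepts a nitrogen-linked group carrying a three-membered ring, for cyclopropylamino gives a 1.0-fold lower number from compound 3 to compound 4 (0.01 log units; within the scatter) when it replaces allyloxy and a 1.0-fold lower number from compound 2 to compound 4 (0.00 log units; within the scatter) when it replaces pentylsulfanyl. Pentyloxy is thus the only group shown that stands apart, since replacing it with cyclopropylamino gives a 5.1-fold higher number from compound 1 to compound 4 (0.71 log units; beyond the scatter) and links through oxygen, sulfur and nitrogen all appear among the three compounds that cannot be told apart. Nothing shown explains why pentyloxy alone differs.

Still open, as far as these compounds go, is whether pentylamino would sit with pentyloxy or with cyclopropylamino, a comparison that would set the linking atom against the chain. Equally open, from the compounds shown here alone, is where a group joined through carbon, such as cyclopentyl, would fall.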